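Removing One Methyl from Compound 2

The source may report more compounds than this note shows. Statements on the series, on what has been measured and on what is new or still open speak of the compounds shown alone.

Measured in an ADME assay on NIH3T3 cells (Mus musculus) for cytotoxicity; a higher number here means that more compound is tolerated, a lower number that less compound is tolerated:
- Compound 1 `CCOC(=O)CN(C)CC#Cc1cc2ncnc(Nc3ccc(OCc4cccc(F)c4)c(Cl)c3)c2s1`: 52 uM
- Compound 2 `CN1CCN(CC#Cc2cc3c(Nc4ccc(OCc5cccc(F)c5)c(Cl)c4)ncnc3s2)CC1`: 6.7 uM

Of these two compounds, compound 2 has the lower number, so the cells tolerate less of it than of compound 1. The gap between the two lies beyond the usual scatter of repeated measurements. Compound 2 therefore stands at the less tolerated end of this small set.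

Compound 3 `Fc1cccc(COc2ccc(Nc3ncnc4sc(C#CCN5CCNCC5)cc34)cc2Cl)c1` has not yet been measured. It comes from compound 2 by a single change: hydrogen in place of methyl on an amine nitrogen in a ring. Hydrogen takes the place of methyl on an amine nitrogen in a ring, so 4-methylpiperazin-1-yl becomes piperazin-1-yl.

Among the compounds with values here, no measured pair shows what a change of this kind does in this assay, so the direction cannot be read from the data. The best guide is the closest measured relative, compound 2 at 6.7 uM. A small expected change, a 1.1-fold lower number from compound 2 to compound 3 (0.05 log units; within the scatter), would stay within the scatter. Compound 3 is estimated at 6 uM. The expected range for compound 3 runs from 2.5 uM to 15 uM.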

Compound 3, half-maximal toxic concentration: 3.9 uM
Compound 3: the middle estimate sits 1.5-fold (0.19 log units) above what was measured; the range from low to high includes it.
By their numbers in this assay, from the lowest: compounds 3 and 2 (each within the scatter of the next); then compound 1.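

In this assay, putting hydrogen in place of methyl on the amine nitrogen in the ring gives a 1.7-fold lower number from compound 2 to compound 3 (0.24 log units; within the scatter), so this single step cannot be told apart from the ordinary spread of repeat measurements. Within the data shown here, this is the first direct reading of the position, which the earlier compounds could not give, as they offered no pair differing in one place: here, going from 4-methylpiperazin-1-yl to piperazin-1-yl leaves no readable mark on how much compound the cells tolerate. Nothing measured here gives a reason for this outcome.

Going by these compounds, a methyl group is a very small change, however, so one step says little about the ring nitrogen in general, and it remains open whether a larger group there, such as a longer chain like 2-hydroxyethyl or an acetyl group, would move the number beyond the scatter. Also open, on these data alone, is whether replacing that nitrogen with an oxygen atom, giving morpholin-4-yl, would leave the cells' tolerance just as unchanged.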